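This account rests on a few compounds, and the source may have more. Where it says the series, first, only, none or still open, it means among the compounds named here.

In a functional assay on G-361 cells (Homo sapiens) for antiproliferative activity, with a stated time of 72 h (on this read-out higher numbers stand for weaker inhibition and lower numbers for stronger inhibition), compound 1 `OC[C@H]1O[C@@H](n2cnc3c(NCc4cccc(F)c4)ncnc32)[C@H](O)[C@@H]1O` gives > 166000 nM as its result, which is a limit of the assay and not a number. Compound 2 `OC[C@H]1O[C@@H](n2cnc3c(NCc4cccc(Br)c4)ncnc32)[C@H](O)[C@@H]1O` gives > 166000 nM as its result, again a limit and not a number. These two differ by bromo in place of fluoro on an aromatic carbon, and that change is a step that the two limits leave unreadable from compound 1 to compound 2 in the data, so it offers no size to carry forward. Compound 3 `COc1cccc(CNc2ncnc3c2ncn3[C@@H]2O[C@H](CO)[C@@H](O)[C@H]2O)c1` has the entry "not determined" (no result reported) in this assay and so stands without a number of its own. The closest guide to its standing is the limit of > 166000 nM in this assay, at which 2 of the 3 values shown sit, and nothing more.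

Compound 4 `OC[C@H]1O[C@@H](n2cnc3c(NCc4cccc(OC(F)(F)F)c4)ncnc32)[C@H](O)[C@@H]1O` departs from compound 3 by trifluoromethyl in place of methyl on an oxygen on an aromatic ring and the change reads trifluoromethyl in place of methyl on an oxygen on an aromatic ring, or methoxy to trifluoromethoxy. Among the measured compounds shown here, no measured step covers this change, and without a value for compound 3 no step size can be read from it. The expectation rests on compound 1 and compound 2 through the limit of > 166000 nM in this assay, at which 2 of the 3 values shown sit, and is for no shift in either direction beyond the scatter, with the result most likely reported again as a limit. For compound 4 the estimated value is 166000 nM with 70000 nM to 250000 nM as the expected range.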

Compound 4, half-maximal inhibitory concentration: > 166000 nM
Compound 4: a limit, no number; the forecaster's own chance of this, stated with the estimate: 80%; the middle value sits exactly at the limit.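

Compound 4 gives only a limit in this assay and so do compound 1 and compound 2, so no step among these three compounds can be read. The compounds shown leave open whether any group on the aromatic ring of the shared core can bring the result to a real number, as all readable results stay at one limit: the limit of > 166000 nM in this assay, at which 3 of the 4 values shown sit.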